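Replacing diethylamino with (carboxymethyl)(methyl)amino: growth inhibition notes

The source may hold more compounds than are shown below. What is called first, only, known or untested is meant among the compounds shown, and "the series" means these compounds.

Measured so far in a functional assay on MCF7 cells (Homo sapiens) for inhibition, read by MTT assay, with a stated time of 48 h, tested at 10 uM; on this read-out higher numbers stand for more inhibition of growth at the one concentration tested and lower numbers for less inhibition of growth:
- compound 1 `CCN(CC)Cc1c(O)c([C@H]2CCN(C)C[C@H]2O)c2oc(C)cc(=O)c2c1O`: 24%
- compound 2 `Cc1cc(=O)c2c(O)c(CN3CCC(N4CCCCC4)CC3)c(O)c([C@H]3CCN(C)C[C@H]3O)c2o1`: 25%

Compound 1 at 24% stands within the scatter of compound 2 at 25%, so these two values cannot be ranked.

Compound 3 `Cc1cc(=O)c2c(O)c(CN(C)CC(=O)O)c(O)c([C@H]3CCN(C)C[C@H]3O)c2o1` has not yet been measured in this assay. Compared with compound 1, it carries (carboxymethyl)(methyl)amino in place of diethylamino on a saturated chain carbon bound to an aromatic carbon. For the measured compounds named here, no two measured compounds differ in only one place, and neither measured compound carries the entering group, so no measured step guides this change.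

The expectation rests only on the closely matched values of compound 1 at 24% and compound 2 at 25%. No step beyond the scatter is expected in this assay, with a slight fall as the tentative direction. The estimated change is a number 4 percentage points lower from compound 1 to compound 3 (within the scatter). For compound 3, the expected value is 20%, within an estimated range of 7% to 33%.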

Compound 3, percent growth inhibition at one concentration: 27%
The estimate for compound 3 lay 7 percentage points below the measured number, within the range that was stated.
By their numbers in this assay, from the lowest: compounds 1, 2 and 3 (each within the scatter of the next).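

In this assay, (carboxymethyl)(methyl)amino in place of diethylamino on a saturated chain carbon bound to an aromatic carbon gives a number 3 percentage points higher from compound 1 to compound 3 (within the scatter). For the compounds shown here, this is the first step read at this place, and it shows that exchanging an ethyl chain of the amine for a chain ending in a carboxylic acid, and the other for a methyl, leaves a result that cannot be told apart from that of compound 1 at this one concentration. Nothing at hand explains this result or links it to any property of either group.

Still open, on these data alone, is whether another group at this place, such as the methyl ester of the same acid, a longer chain ending in a carboxylic acid, or morpholine as the amine, would give a step beyond the scatter. Also open, as far as these compounds go, is whether compound 1 and compound 3 would remain indistinguishable at other concentrations, since a single-concentration read-out says nothing about the shape of their concentration responses.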